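This account rests on a few compounds, and the source may have more. Where it says the series, first, only, none or still open, it means among the compounds named here.

In a functional assay on HT cells (Homo sapiens) for antiproliferative activity, read by fluorescence, with a stated time of 72 h (a lower number here means a stronger inhibitor of growth, a higher number a weaker inhibitor of growth), two compounds with the same core have been measured. Compound 1 `CC(C)c1n[nH]c2c(NCc3ccc(-c4ccccn4)cc3)nc(SC[C@H](O)CN)nc12`, which carries 3-amino-2-hydroxypropyl on a sulfur, gives 63 nM. Compound 2 `CC(C)c1n[nH]c2c(NCc3ccc(-c4ccccn4)cc3)nc(S)nc12`, with hydrogen on that sulfur, gives 2760 nM, the higher of the two numbers. Compound 3 `CC(C)c1n[nH]c2c(NCc3ccc(-c4ccccn4)cc3)nc(SCCCN)nc12` differs from compound 2 at that one place, with 3-aminopropyl in place of hydrogen on a sulfur. Within the data shown here, the only measured step bearing on this change is a 44-fold higher number from compound 1 to compound 2 (1.64 log units; beyond the scatter), which is large and beyond the scatter. Among the measured compounds shown here, the new chain reverses that kind of change, although it lacks the hydroxyl of the chain in compound 1, and no measured step isolates that hydroxyl. A large step towards a lower number is therefore expected, estimated as a 28-fold lower number from compound 2 to compound 3 (1.44 log units; beyond the scatter). For compound 3 the expected value is 100 nM, within an estimated range of 30 nM to 350 nM.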

Compound 3, concentration for 50% growth inhibition: 120 nM
Estimate against measurement, compound 3: 1.2-fold (0.08 log units) below; the measured number falls inside the stated range.
By their numbers in this assay, from the lowest: compounds 1 and 3 (each within the scatter of the next); then compound 2.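

In this assay, 3-aminopropyl on the sulfur produces a large change without any hydroxyl on the chain (a 23-fold lower number from compound 2 to compound 3 (1.36 log units; beyond the scatter)). The hydroxy group can now be read on its own, and removing it leaves the number within the scatter (a 1.9-fold higher number from compound 1 to compound 3 (0.28 log units; within the scatter)). The large step seen earlier (a 44-fold higher number from compound 1 to compound 2 (1.64 log units; beyond the scatter)) therefore does not depend on that hydroxyl in this pair of chains. Nothing available explains why the chain on the sulfur matters so much.

The compounds shown leave open whether the terminal amine is needed, which a propyl chain ending in a hydroxyl or a carboxylic acid would test. They also leave open how a shorter or longer amine chain, or a piperidine on the sulfur, would compare.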